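The source may report more compounds than this note shows. Statements on the series, on what has been measured and on what is new or still open speak of the compounds shown alone.

Compound 2 `CN(c1cc2ncc(=O)[nH]c2cc1NC(=S)NC(=O)/C=C/c1ccccc1)C1CCCCC1` and compound 1 `CN(c1cc2ncc(=O)[nH]c2cc1NC(=S)NC(=O)c1ccc(OC(F)(F)F)cc1)C1CCCCC1` share a core and differ only in the group on the carbonyl carbon. In an ADME assay on Huh-7 cells (Homo sapiens) for cytotoxicity (on this read-out higher numbers stand for weaker inhibition and lower numbers for stronger inhibition), compound 1 gives 6470 nM, and compound 2 gives 11000 nM. Compound 2 has the highest of the two numbers, but the step of a 1.7-fold higher number from compound 1 to compound 2 (0.23 log units; within the scatter) is within the scatter, so the two compounds cannot be told apart on this read-out. Compound 3 `CN(c1cc2ncc(=O)[nH]c2cc1NC(=S)NC(=O)c1cccc2ccccc12)C1CCCCC1` is not yet measured; it carries naphthalen-1-yl in place of 2-phenylethenyl on a carbonyl carbon. Going by the values given here, the only step that bears on this change is the one from compound 1 to compound 2, which also exchanged the group on the carbonyl carbon and stayed within the scatter. A similar outcome is therefore expected for compound 3, with no step beyond the scatter in this assay; the expected step is a 1.2-fold lower number from compound 2 to compound 3 (0.09 log units; within the scatter). Compound 3 is estimated at 9000 nM, within a range of 3000 nM to 27000 nM.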

Compound 3, half-maximal inhibitory concentration: 9980 nM
Estimate against measurement, compound 3: 1.1-fold (0.04 log units) below; measured number inside the range.
By their numbers in this assay, from the lowest: compounds 1, 3 and 2 (each within the scatter of the next).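

On the carbonyl carbon, naphthalen-1-yl brings a second six-membered aromatic ring and removes the double bond outside the rings of 2-phenylethenyl, yet this assay shows a 1.1-fold lower number from compound 2 to compound 3 (0.04 log units; within the scatter) and no separation follows from this exchange. Against 4-(trifluoromethoxy)phenyl, the same position gives a 1.5-fold higher number from compound 1 to compound 3 (0.19 log units; within the scatter) and so, with all three pairs now within the scatter, the three groups tried here cannot be told apart on this read-out, and none of the three compounds goes against this. No measurement is available to account for this absence of separation.

The compounds shown leave open whether a different kind of group on this carbonyl carbon, such as an amine, a carboxylic acid or a longer alkyl chain, would produce a step beyond the scatter. They also leave open whether a change elsewhere on the shared core would do so.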